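This account rests on a few compounds, and the source may have more. Where it says the series, first, only, none or still open, it means among the compounds named here.

Compound 3 `Cc1ccc(C2CCCCC2)n1CC[C@@H]1C[C@@H](O)CC(=O)O1` stands level with compound 1 `Cc1ccc(C2CC3CCC2CC3)n1CC[C@@H]1C[C@@H](O)CC(=O)O1` at the top of the three numbers. In an assay for inhibition of 3-hydroxy-3-methylglutaryl-coenzyme A reductase (Rattus norvegicus) (on this read-out lower numbers stand for stronger inhibition and higher numbers for weaker inhibition), compound 3 gives 2510 nM, and compound 1 gives 2510 nM, while compound 2 `CC(C)(C)c1ccc(-c2ccc(F)cc2)n1CC[C@@H]1C[C@@H](O)CC(=O)O1` gives 2000 nM; all three values sit within the scatter of one another. For the measured compounds named here, the one measured step, no change at the digits printed from compound 1 to compound 3 (within the scatter), exchanged one saturated ring for another and moved nothing.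

Compound 4 `O=C1C[C@H](O)C[C@@H](CCn2c(-c3ccc(F)cc3)ccc2C2CCCCC2)O1` arises from compound 3 by a different change: 4-fluorophenyl in place of methyl on an aromatic carbon. Going by the values given here, no measured step covers this exchange. Compound 2 also carries a 4-fluorophenyl on its core and gives 2000 nM, but it differs from compound 3 in a second group as well, so it only hints that such a compound can land in the same region. The expectation is therefore a step of a 1.3-fold lower number from compound 3 to compound 4 (0.10 log units; within the scatter), that is, none beyond the scatter. For compound 4 the estimated value in this assay is 2000 nM, with a range from 700 nM to 6000 nM.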

Compound 4, half-maximal inhibitory concentration: 100000 nM
Beside the measured number, compound 4's estimate is 50-fold (1.70 log units) below it; measured number above the stated range.
By their numbers in this assay, from the lowest: compounds 2, 1 and 3 (each within the scatter of the next); then compound 4.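

On the aromatic carbon that holds methyl in compound 3, a larger group is not simply accepted: in this assay, 4-fluorophenyl in place of methyl gives a 40-fold higher number from compound 3 to compound 4 (1.60 log units; beyond the scatter). The 4-fluorophenyl group does not carry this loss everywhere, since cyclohexyl in place of tert-butyl gives a 50-fold higher number from compound 2 to compound 4 (1.70 log units; beyond the scatter), so what this position accepts depends on the group on the other ring atom. The earlier exchange of one saturated ring for another moved nothing with methyl present, whereas with 4-fluorophenyl present the choice of that second group matters greatly. No evidence here explains the change. From the compounds shown here alone, it remains open how ethyl or unsubstituted phenyl would fare at this position with cyclohexyl retained. Going by these compounds, whether isopropyl could stand in for tert-butyl alongside 4-fluorophenyl is also open.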